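Moving from fluorophenyl to dimethylphenyl on the ring nitrogen

The source may hold more compounds than are shown below. What is called first, only, known or untested is meant among the compounds shown, and "the series" means these compounds.

In a functional assay on HL-60 cells (Homo sapiens) for inhibition, read by MTT assay, with a stated time of 72 h (a higher number here means a weaker inhibitor, a lower number a stronger inhibitor), compound 3 `Cc1nc(-c2ccccc2)c(C(=O)N2CCN(c3ccccc3F)CC2)o1` gives 147 nM, the higher of the two numbers reported. Going by the values given here, its nearest neighbour, compound 1 `Cc1nc(-c2ccccc2)c(C(=O)N2CCN(c3ccccc3Cl)CC2)o1`, gives 124 nM in this assay; the single step of a 1.2-fold higher number from compound 1 to compound 3 (0.07 log units; within the scatter) is within the scatter. Compound 2 `C=C(C)c1ccc(N2CCN(C(=O)c3oc(C)nc3-c3ccccc3)CC2)cc1` is "not active" (no number reported) in this assay, with no number reported. Compound 4 `Cc1nc(-c2ccccc2)c(C(=O)N2CCN(c3ccc(C)c(C)c3)CC2)o1` differs from compound 3 by 3,4-dimethylphenyl in place of 2-fluorophenyl on an amine nitrogen in a ring. Among the compounds with values here, no measured step matches this change; the one step on hand is small and concerns a halogen exchange only, while compound 2 shows that another replacement at the same ring nitrogen can abolish activity. Compound 4 is therefore expected to show a weakening step, a 2.7-fold higher number from compound 3 to compound 4 (0.43 log units; beyond the scatter), with an estimated value of 400 nM and a range from 120 nM to 2500 nM.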

Compound 4, half-maximal inhibitory concentration: 43 nM
Beside the measured number, compound 4's estimate is 9.3-fold (0.97 log units) above it; the measured number lies below the stated range.
By their numbers in this assay, from the lowest: compound 4; then compounds 1 and 3 (each within the scatter of the next).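

At the ring nitrogen, 3,4-dimethylphenyl in place of 2-fluorophenyl gives a 3.4-fold lower number from compound 3 to compound 4 (0.53 log units; beyond the scatter) in this assay, and in place of 2-chlorophenyl it gives a 2.9-fold lower number from compound 1 to compound 4 (0.46 log units; beyond the scatter). Going by these compounds alone, the halogen exchange had left the number within the scatter, so this is the first sign that the aryl group here can move the number towards a stronger inhibitor. Lacking a halogen does not settle the outcome, however: compound 2, also without one, is "not active" (no number reported).

Going by these compounds, whether the gain needs both methyl groups, and whether a methoxy group or an amine on that phenyl ring would keep it, remains open. Nothing available explains the gain.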